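Propanoyl to acetyl: the next step in the series

This account rests on a few compounds, and the source may have more. Where it says the series, first, only, none or still open, it means among the compounds named here.

Of the compounds shown here, two carry numbers so far. Compound 1 `CC(=O)N[C@@H](C)C(=O)N(C)/N=N/c1ccc(Br)cc1` in a physicochemical assay for lipophilicity, read by HPLC, in phosphate buffer, measured as octanol-water partition, at pH 7.4 (a lower number here means a more polar compound, a higher number a more lipophilic compound), gives 2.8. Compound 2 `CCC(=O)N[C@@H](C)C(=O)N(C)/N=N/c1ccc(C#N)cc1` in this assay gives 1.87, the lower of the two numbers, and the gap to compound 1 lies beyond the scatter. The two structures differ in more than one place, so nothing beyond the two values themselves is read from that pair.

Compound 3 `CC(=O)N[C@@H](C)C(=O)N(C)/N=N/c1ccc(C#N)cc1` is the next one to be measured in this assay. It differs from compound 2 in one place: hydrogen in place of methyl on a saturated chain carbon bound to a carbonyl carbon. Among the measured compounds shown here, no pair of measured compounds is separated by this single change, so the size of the step has no direct anchor in the numbers at hand and can only be an expectation.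

The step is expected to run downward, at a number 0.47 log units lower from compound 2 to compound 3 (beyond the scatter), a shift a little beyond the scatter rather than within it. Compound 3 is accordingly estimated in this assay at 1.4, with a range of 1 to 1.8.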

Compound 3, partition coefficient: 1.41
The estimate for compound 3 lay 0.01 log units below the measured number; low and high end bracket the measured number.
By their numbers in this assay, from the lowest: compound 3; then compound 2; then compound 1.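

In this assay the chain position now has a step of its own: propanoyl to acetyl, hydrogen in place of methyl on a saturated chain carbon bound to a carbonyl carbon, gives a number 0.46 log units lower from compound 2 to compound 3 (beyond the scatter), a modest change. Among the compounds shown here, compound 3 also makes the aromatic position readable for the first time, since it shares everything with compound 1 except the group on the aromatic carbon, and cyano in place of bromo gives a number 1.39 log units lower from compound 1 to compound 3 (beyond the scatter), a large change. On this one example of each, the step on the aromatic carbon is the large one and the step on the chain carbon the modest one, and both lie beyond the scatter.

No supporting measurement at hand bears on what lies behind either step. Still open, on these data alone, are whether the chain step keeps its size with bromo on the aromatic carbon, how a longer chain such as butanoyl would extend it, and what an amine or a carboxylic acid on the aromatic carbon would give.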